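This account rests on a few compounds, and the source may have more. Where it says the series, first, only, none or still open, it means among the compounds named here.

Measured so far:
Compound 1, `CN(C)CCNc1nc(-c2ccc(NC(=O)Nc3ccccc3F)cc2)nc2ccsc12`, in a functional assay on HT-29 cells (Homo sapiens) for cytotoxicity, read by MTT assay, with a stated time of 72 h (on this read-out higher numbers stand for weaker inhibition and lower numbers for stronger inhibition), compound 1 gives 510 nM.
Compound 2, `CN(C)CCNc1nc(-c2ccc(NC(=O)Nc3ccccc3Cl)cc2)nc2ccsc12`, in this assay compound 2 gives 310 nM.

Compound 2 holds the lowest of the two numbers shown, and its nearest neighbour is compound 1; the difference between them, a 1.6-fold lower number from compound 1 to compound 2 (0.22 log units; within the scatter), comes from a single change, chloro in place of fluoro on an aromatic carbon, and it falls inside the scatter, so the two cannot be told apart on these data.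

The next compound, compound 3, `CCN(CC)CCCNc1nc(-c2ccc(NC(=O)Nc3ccccc3Cl)cc2)nc2ccsc12`, keeps the chloro-bearing ring of compound 2 and changes only the amine-bearing side chain: (diethylamino)methyl in place of dimethylamino on a saturated chain carbon, two bonds along the chain from a nitrogen on an aromatic ring. For the measured compounds named here, no measured pair touches this side chain, so the only step on record, the halogen swap from compound 1 to compound 2, does not bear on it. With nothing to point either way, no step beyond the scatter is expected in this assay. The estimate for compound 3 is therefore 320 nM, within the range 110 nM to 950 nM, which amounts to an expected step of a 1.0-fold higher number from compound 2 to compound 3 (0.01 log units; within the scatter).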

Compound 3, half-maximal inhibitory concentration: 340 nM
The estimate for compound 3 lay 1.1-fold (0.03 log units) below the measured number; measured number inside the range.
By their numbers in this assay, from the lowest: compounds 2, 3 and 1 (each within the scatter of the next).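

In this assay, the swap of the 2-(dimethylamino)ethyl chain for the 3-(diethylamino)propyl chain gives a 1.1-fold higher number from compound 2 to compound 3 (0.04 log units; within the scatter) and so leaves the two compounds indistinguishable on this read-out. For the compounds shown here, this is the first measured pair that touches the amine-bearing side chain, and it shows that, with the chloro-bearing ring kept, this position can take (diethylamino)methyl with 6 heavy atoms in place of dimethylamino with 3 without a step beyond the scatter. Nothing at hand offers a reason for this result.

The single step alters both the chain itself and the groups on its terminal nitrogen, so the compounds shown cannot say what each of these alterations does alone, and a partial effect of one could be offset by the other. It also remains open whether this tolerance extends to a ring amine such as morpholine or piperidine, to a carboxylic acid at the end of the chain, or to a still longer chain, since every side chain shown ends in an open-chain tertiary amine.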